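Replacing the acetyl of compound 3

The source may report more compounds than this note shows. Statements on the series, on what has been measured and on what is new or still open speak of the compounds shown alone.

- compound 1 `NC(=O)N/N=C/c1ccc(OCc2ccc3no[n+]([O-])c3c2)cc1`: > 200 uM
- compound 2 `O=Cc1cccc(OCc2ccc3no[n+]([O-])c3c2)c1`: 50 uM
- compound 3 `CC(=O)c1ccccc1OCc1ccc2no[n+]([O-])c2c1`: > 200 uM

In an ADME assay on cells (Erythrocyte, Homo sapiens), read by spectrophotometry and hemolysis, with a stated time of 24 h (a higher number here means a weaker inhibitor, a lower number a stronger inhibitor), compound 3 gives > 200 uM, which is a limit. Compound 1 gives > 200 uM, also a limit. Across the series, the readings show (the limit of > 200 uM in this assay, at which 2 of the 3 values shown sit). Compound 2 gives a true number, 50 uM, so such numbers do occur among these compounds. Compound 4 `C/C(=N/NC(=N)N)c1ccccc1OCc1ccc2no[n+]([O-])c2c1` carries a group with no common name in place of the acetyl, on an aromatic carbon: a group of 7 heavy atoms (3 carbon, 4 nitrogen; no ring) in place of a group of 3 heavy atoms (2 carbon, 1 oxygen; no ring), on an aromatic carbon. An estimated step of an at least 1.6-fold lower number from compound 3 to compound 4 (0.22 log units; that floor lies within the scatter) is expected, toward a lower number, though a reading at the limit remains quite possible. For compound 4 the expected value is 120 uM, within an estimated range of 40 uM to 300 uM.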

Compound 4, concentration for 50% inhibition: > 200 uM
Compound 4 gave a limit, no number; the forecaster's own chance of this, stated with the estimate: 50%; middle value at least 1.6-fold (0.22 log units) from the limit.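

No step can be read between compound 3 and compound 4, as both readings are limits of the assay. The compounds shown leave open whether the group replacing the acetyl changes the reading at all, in either direction.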